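This account rests on a few compounds, and the source may have more. Where it says the series, first, only, none or still open, it means among the compounds named here.

Measured so far in an ADME assay on the whole organism (Mus musculus, strain CD1) for pharmacokinetics, at a dose of 10 mg/kg by the oral route; on this read-out higher numbers stand for higher exposure at the dose given and lower numbers for lower exposure
compound 1 `CN1CCC(Oc2ccc(N3C(=S)N(c4cnc(C#N)c(C(F)(F)F)c4)C(=O)C34CCC4)cn2)CC1` gives 1300 nM here
compound 2 `Cc1cc(N2C(=O)C3(CCC3)N(c3ccc(OC4CCNCC4)nc3)C2=S)cnc1C#N` gives 1880 nM here

Compound 2 at 1880 nM lies within the usual scatter of compound 1 at 1300 nM on these numbers. Compound 3 `N#Cc1ncc(N2C(=O)C3(CCC3)N(c3ccc(OC4CCNCC4)nc3)C2=S)cc1C(F)(F)F` has trifluoromethyl in place of methyl on an aromatic carbon of compound 2, ortho to a cyano group trifluoromethyl in place of methyl on an aromatic carbon in the counted terms. Among the compounds with values here, no measured pair shows this change alone. Compound 1 also carries trifluoromethyl but differs from compound 2 elsewhere too, so it offers only indirect guidance. Since compound 1 at 1300 nM stays within the scatter of compound 2, no shift beyond the scatter is expected in this assay for this change. An estimated 1.2-fold lower number from compound 2 to compound 3 (0.07 log units; within the scatter) is expected to stay within the scatter. For compound 3 the expected value is 1600 nM with an estimated range from 700 nM to 3500 nM in this measurement.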

Compound 3, maximal plasma concentration: 660 nM
Compound 3: the middle estimate sits 2.4-fold (0.38 log units) above what was measured, and the stated range ends above it.
By their numbers in this assay, from the lowest: compounds 3, 1 and 2 (each within the scatter of the next, the first and the last beyond it).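

In this assay, within the data shown here, the aromatic carbon ortho to a cyano group now has a single-change pair: trifluoromethyl in place of methyl gives a 2.8-fold lower number from compound 2 to compound 3 (0.45 log units; beyond the scatter) and is the only step so far to clear the scatter. At the amine nitrogen in a ring, with trifluoromethyl held constant, hydrogen in place of methyl gives a 2.0-fold lower number from compound 1 to compound 3 (0.29 log units; within the scatter) and so cannot be told apart from repeat variation on this read-out. Nothing shown identifies what lies behind the step at the aromatic position.

On these data alone, whether a chlorine atom, an ethyl group or a methoxy group at this aromatic carbon would read closer to compound 2 or to compound 3 remains open. Also open, as far as these compounds go, is whether the methyl-to-trifluoromethyl step has the same size when the amine nitrogen carries methyl or a longer chain.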